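The source may hold more compounds than are shown below. What is called first, only, known or untested is meant among the compounds shown, and "the series" means these compounds.

Working notes on the series. In a functional assay on UO-31 cells (Homo sapiens) for antiproliferative activity, read by sulforhodamine B assay, with a stated time of 72 h (on this read-out higher numbers stand for weaker inhibition and lower numbers for stronger inhibition), compound 1 `CCN1C(=O)CS/C1=N/Nc1nncc2ccccc12` gives 54 nM, and compound 2 `C(=C/c1ccccc1)\C(=N\Nc1nncc2ccccc12)c1ccccc1` gives 3.9 nM. Compound 2 therefore holds the lower of the two numbers, and the gap to compound 1 lies beyond the scatter. Going by the values given here, these two compounds differ in more than one place, so no measured single-change step is available to guide the next comparison.

Compound 3 `Clc1ccc(C(/C=C/c2ccccc2)=N\Nc2nncc3ccccc23)cc1` differs from compound 2 by the change from phenyl to 4-chlorophenyl, with chloro in place of hydrogen on an aromatic carbon. In this assay, no step beyond the scatter is expected for this single substitution, and no direction is favoured. The expected 1.3-fold higher number from compound 2 to compound 3 (0.11 log units; within the scatter) is accordingly small. For compound 3 the estimated value is 5 nM, with an expected range of 1.5 nM to 20 nM.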

Compound 3, half-maximal inhibitory concentration: 6.2 nM
Compound 3: middle estimate off by 1.2-fold (0.09 log units), on the low side; the measured number falls inside the stated range.
By their numbers in this assay, from the lowest: compounds 2 and 3 (each within the scatter of the next); then compound 1.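

In this assay, chloro in place of hydrogen on an aromatic carbon, para to a large group, gives a 1.6-fold higher number from compound 2 to compound 3 (0.20 log units; within the scatter), so this position takes a chlorine atom with no step beyond the scatter. The earlier pair differed in more than one place and could not show this for any single position. No measured evidence bears on the reason the number holds through this change.

Open, on these data alone, is whether another group at the same place, such as an amine, a carboxylic acid or a methoxy group, would also stay within the scatter of compound 2. Also open, as far as these compounds go, is whether the change from phenyl to 4-chlorophenyl gives a similar step elsewhere on the molecule, since this single pair speaks only for this one position on this one ring.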